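Swapping butyl for cyclopentyl on a low-toxicity core

The source may hold more compounds than are shown below. What is called first, only, known or untested is meant among the compounds shown, and "the series" means these compounds.

Of the compounds shown here, three sharing one core have been tested in an ADME assay on Akata cells (Homo sapiens) for cytotoxicity, with a stated time of 7 days; on this read-out higher numbers stand for lower toxicity in this test and lower numbers for higher toxicity in this test. Compound 1, `CCCOc1nc(N)nc2c1ncn2/C=C1/CC1(CO)CO`, gives > 20000 nM there, which is a limit of the assay rather than a number. Compound 2, `CCCCNc1nc(N)nc2c1ncn2/C=C1/CC1(CO)CO`, gives > 24000 nM in this assay, again a limit and not a number. Compound 3, `Nc1nc2c(ncn2/C=C2/CC2(CO)CO)c(=O)[nH]1`, gives > 20000 nM, also a limit. The one step that connects two of these compounds, a step that the two limits leave unreadable from compound 1 to compound 2, is unreadable: both of its ends are limits. So compound 2 stands only at a limit, and its two companions stand at limits as well, as the limit of > 20000 nM in this assay, at which 2 of the 3 values shown sit, and the limit of > 24000 nM in this assay, at which 1 of the 3 values shown sits, show.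

Compound 4, `Nc1nc(NC2CCCC2)c2ncn(/C=C3/CC3(CO)CO)c2n1`, differs from compound 2 in one place: cyclopentyl in place of butyl on a nitrogen on an aromatic ring. No measured step tells how this change moves the read-out, and the only step shown cannot be read. For compound 4 the expected step is therefore a step that the limit leaves unreadable from compound 2 to compound 4, that is, no movement beyond the scatter, and a limit is again the most likely outcome. The estimated value for compound 4 is 25000 nM, with a range from 10000 nM to 60000 nM.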

Compound 4, half-maximal cytotoxic concentration: > 20000 nM
Compound 4: a limit, no number (the forecaster's own chance of this, stated with the estimate: 85%); the middle value does not contradict the limit.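

Compound 4 gives > 20000 nM, a limit of the assay and not a number. Its steps from compound 1 and from compound 2 therefore cannot be read. It stays open whether propoxy, butylamino and cyclopentylamino on the shared core differ at all in cytotoxicity, with no compound shown giving a number.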